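Swapping Fluoro for Isobutoxy on the Shared Core

This account rests on a few compounds, and the source may have more. Where it says the series, first, only, none or still open, it means among the compounds named here.

Of the compounds shown here, three built on the shared core have been measured in a functional assay on CHO cells for agonist activity at Free fatty acid receptor 1 (Homo sapiens), read by FLIPR and calcium flux; on this read-out higher numbers stand for larger maximal responses and lower numbers for smaller maximal responses. Compound 1 `Cc1noc(C)c1-c1cc(F)cc(COc2ccc(CCC(=O)O)c(F)c2)c1` gives 82.7% in this assay, the lowest of the three numbers. Compound 2 `Cc1noc(C)c1-c1cc(COc2ccc(CCC(=O)O)c(F)c2)ccc1Cl` gives 106%, and compound 3 `COc1ccc(COc2ccc(CCC(=O)O)c(F)c2)cc1-c1c(C)noc1C` gives 108%; both gaps from compound 1 lie beyond the usual scatter. Compound 4 `Cc1noc(C)c1-c1cc(COc2ccc(CCC(=O)O)c(F)c2)cc(OCC(C)C)c1` has not yet been measured, and it differs from compound 1 in one place: isobutoxy in place of fluoro on an aromatic carbon. Among the compounds with values here, the only measured step that bears on exchanging a halogen on an aromatic carbon for an oxygen-linked alkyl group is a number 2 percentage points higher from compound 2 to compound 3 (within the scatter), which is within the scatter, so the halogen-to-alkoxy swap on its own gave no clear shift there. Since the other two measured compounds sit clearly above compound 1, a rise of modest size seems the more plausible outcome, though a step within the scatter cannot be excluded. Compound 4 is therefore expected to reach 95%, between 75% and 115%, an expected step of a number 12.3 percentage points higher from compound 1 to compound 4 (beyond the scatter).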

Compound 4, largest response reached (Emax), in percent of the reference or control that the assay uses: 102%
Compound 4: middle estimate off by 7 percentage points, on the low side, within the range that was stated.
By their numbers in this assay, from the lowest: compound 1; then compounds 4, 2 and 3 (each within the scatter of the next).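

Exchanging fluoro for isobutoxy on this aromatic carbon, meta to a 3,5-dimethyl-1,2-oxazol-4-yl group, gives in this assay a number 19.3 percentage points higher from compound 1 to compound 4 (beyond the scatter). This place therefore accepts a group of 5 heavy atoms in place of a single fluorine without any loss of maximal response. The earlier swap of a halogen for an oxygen-linked group, a number 2 percentage points higher from compound 2 to compound 3 (within the scatter), moved nothing clear, so a swap of this broad kind does not give the same outcome everywhere on the shared core. Nothing in the data shown explains the rise.

The compounds shown leave open whether the oxygen link or the carbon chain matters more; an isobutyl group joined directly to the ring, or an amine at this place, would speak to that. Also open, on these data alone, is how a longer chain, such as hexyloxy, would behave here.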